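Swapping an Ester for a Bromophenyl Group on a Coumarin-Type Core

The source may report more compounds than this note shows. Statements on the series, on what has been measured and on what is new or still open speak of the compounds shown alone.

Of the compounds shown here, two with a shared core have been measured in a functional assay on PC-12 cells (Rattus norvegicus) for cytotoxicity, read by MTT assay, with stated times of 3 h and 2 h, tested at 50 uM; a lower number here means a weaker effect, a higher number a stronger effect of the compound at the concentration tested. Compound 1 `Cc1cc(=O)oc2cc(OCCCn3cc(CNC(=O)CCCCC4CCSS4)nn3)ccc12` gives 75.4%. Compound 2 `CCOC(=O)c1cc2ccc(OCCCn3cc(CNC(=O)CCCCC4CCSS4)nn3)cc2oc1=O` gives 49.2%, the lower of the two numbers, a gap beyond the usual scatter. Compound 3 `O=C(CCCCC1CCSS1)NCc1cn(CCCOc2ccc3cc(-c4ccc(Br)cc4)c(=O)oc3c2)nn1` is not yet measured; it differs from compound 2 in one place: 4-bromophenyl in place of ethoxycarbonyl on an aromatic carbon. Within the data shown here, no measured pair shows a change of this kind, so the size of the step is open. A modest rise in this assay is expected, a number 6.8 percentage points higher from compound 2 to compound 3 (within the scatter). Compound 3 is estimated at 56%, within a range from 35% to 77%.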

Compound 3, a percentage reported as activity, at one concentration (the size of the read-out at that concentration, not a potency): 74.7%
Beside the measured number, compound 3's estimate is 18.7 percentage points below it; the range from low to high includes it.
By their numbers in this assay, from the lowest: compound 2; then compounds 3 and 1 (each within the scatter of the next).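

Swapping at this aromatic carbon clearly moves the read-out: in this assay, 4-bromophenyl in place of ethoxycarbonyl gives a number 25.5 percentage points higher from compound 2 to compound 3 (beyond the scatter) for this single change. So this position accepts a larger group with an aromatic ring and no hydrogen-bond acceptors, and the effect at the tested concentration does not fall. Nothing available explains why the number moves.

Going by these compounds, it remains open whether the ring or the bromine accounts for the step. A plain phenyl, an amine or a carboxylic acid at this position could help separate these possibilities.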